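A few compounds are considered here, and "the series" means these few. Any claim that something is new, unique, unknown or untested is made for them only; others in the source may bear on it.

Compound 1 `c1ccc(CNc2[nH]ccc3ncnc2-3)cc1` — 57%
Compound 2 `OC[C@H]1OC(n2cnc3c(Nc4ccccc4)nccc32)[C@H](O)[C@@H]1O` — 10%
Compound 3 `OC[C@H]1O[C@@H](n2cnc3c(S)nccc32)C[C@@H]1O` — < 5%

In a functional assay on EL4 cells (Mus musculus) for inhibition, tested at 100 uM (a lower number here means less inhibition, a higher number more inhibition at the concentration tested (going by the name of the read-out)), compound 1 gives 57% and compound 2 gives 10%. For compound 3 the reading < 5% is a limit of this assay, not a measured number. Compound 3 sits at the limit of < 5% in this assay, at which 1 of the 3 values shown sits. Compound 4 `OC[C@H]1O[C@@H](n2cnc3c(SCc4ccccc4)nccc32)C[C@@H]1O` has not yet been tested in this assay; it differs from compound 3 by benzyl in place of hydrogen on a sulfur. Compound 1, which also carries a benzyl group, gives 57%, so a rise from compound 3 to compound 4 is expected rather than no change, though compound 2 gives 10%, which tempers that expectation. The step expected here is a number at least 10 percentage points higher from compound 3 to compound 4 (that floor lies within the scatter). Compound 4 is estimated at 15%, with a likely range from 5% to 40%.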

Compound 4, a percentage reported as inhibition, at one concentration (the size of the read-out at that concentration, not a potency): 11%
For compound 4 the middle estimate is 4 percentage points above the measured one, and the stated range covers the measured number.
By their numbers in this assay, from the lowest: compounds 2 and 4 (each within the scatter of the next); then compound 1. At a limit, below all of these: compound 3.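

With benzyl in place of hydrogen on a sulfur, this assay shows a number at least 6 percentage points higher from compound 3 to compound 4 (that floor lies within the scatter) and so gives no firm sign that this large group changes inhibition at this position. Adding the benzyl ring here does not clearly raise the reading. From the compounds shown here alone, compound 3 stands at a limit, not a number, so the true size of the step stays unknown: the limit of < 5% in this assay, at which 1 of the 4 values shown sits.

The compounds shown leave open whether a smaller group on this sulfur, such as methyl, would read differently. A longer chain ending in an amine or a carboxylic acid is also left open.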